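This account rests on a few compounds, and the source may have more. Where it says the series, first, only, none or still open, it means among the compounds named here.

Measured compounds:
compound 1 `CCCCOC(=O)NS(=O)(=O)c1ccc(CCC)cc1-c1ccc(Cn2c(-c3nccs3)nc3ccccc32)cc1`, 0.0833 h
compound 2 `CCCc1ccc(S(=O)(=O)NC(=O)OCCCC(F)(F)F)c(-c2ccc(Cn3c(C(C)(C)C)nc4ccccc43)cc2)c1`, 0.1 h

In an ADME assay on microsomes from liver (Mus musculus, strain CD-1) for metabolic stability, read by LC-MS, using NADPH, with stated times of 5 min and 60 min, tested at 1 uM (on this read-out higher numbers stand for a longer-lived compound and lower numbers for a shorter-lived compound), compound 1 gives 0.0833 h. Compound 2 gives 0.1 h in this assay, a number within the scatter of that of compound 1, so the two stand together and neither is set apart. Compound 3 `CCCCOC(=O)NS(=O)(=O)c1ccc(CCC)cc1-c1ccc(Cn2cnc3ccccc32)cc1` differs from compound 1 by hydrogen in place of 1,3-thiazol-2-yl on an aromatic carbon. Among the measured compounds shown here, no measured pair shows such a change, so no step size is known for it. Compound 3 is expected to give 0.1 h in this assay, within 0.05 h to 0.3 h. The expected step of a 1.2-fold higher number from compound 1 to compound 3 (0.08 log units; within the scatter) is therefore small, not beyond the scatter.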

Compound 3, half-life: 0.0833 h
Compound 3: the middle estimate sits 1.2-fold (0.08 log units) above what was measured; the range from low to high includes it.
By their numbers in this assay, from the lowest: compounds 1, 3 and 2 (each within the scatter of the next).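

In this assay, among the compounds shown here, hydrogen in place of 1,3-thiazol-2-yl on an aromatic carbon between two ring nitrogen atoms brings no change at the digits printed from compound 1 to compound 3 (within the scatter), the first comparison here of compounds that differ in one place. At this position, the whole five-membered aromatic ring can therefore go without a half-life change beyond the scatter. No measurement shown bears on the reason for this result. Still open, going by these compounds, is whether an amine, a carboxylic acid or a longer chain at this position would shift the half-life beyond the scatter.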